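This account rests on a few compounds, and the source may have more. Where it says the series, first, only, none or still open, it means among the compounds named here.

Measured compounds:
compound 1, `CCOC(=O)C1=C(Nc2ccccc2)S/C(=C\c2ccc(Br)c(O)c2)C1=O`: 13.6%
compound 2, `CCOC(=O)C1=C(Nc2ccc(OC)cc2)S/C(=C\c2ccc[nH]2)C1=O`: < 10%

In a functional assay on A549 cells (Homo sapiens) for inhibition, read by MTT assay, with a stated time of 72 h, tested at 10 uM (a lower number here means less inhibition, a higher number more inhibition at the concentration tested (going by the name of the read-out)), compound 1 gives 13.6%. Compound 2 does not give a number in this assay, only a limit, < 10%, so compound 2 stands at the floor of what is reported (the limit of < 10% in this assay, at which 1 of the 2 values shown sits). Among the compounds with values here, both values shown sit low, and with one of them a limit, no step between compound 1 and compound 2 can be sized here.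

Compound 3, `CCOC(=O)C1=C(Nc2ccc(C(F)(F)F)cc2)S/C(=C\c2ccc[nH]2)C1=O`, has not been measured in this assay. It differs from compound 2 in one place: trifluoromethyl in place of methoxy on an aromatic carbon.

Within the data shown here, no measured step involves this exchange, so the expectation for compound 3 rests on the standing of compound 2, whose result in this assay is the limit < 10%. The step from compound 2 to compound 3 is expected to be small, a number at least 2 percentage points higher from compound 2 to compound 3 (that floor lies within the scatter), and not beyond the scatter in either direction. For compound 3 in this assay an inhibition of 12% is estimated, within a range of 0% to 35%, with a fair chance that only a limit is reported again.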

Compound 3, a percentage reported as inhibition, at one concentration (the size of the read-out at that concentration, not a potency): 30.1%
Compound 3: the middle estimate sits 18.1 percentage points below what was measured, and the stated range covers the measured number.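

In this assay, trifluoromethyl in place of methoxy, on an aromatic carbon para to a large group, gives a number at least 20.1 percentage points higher from compound 2 to compound 3 (beyond the scatter). With the rest of the structure unchanged, this position is not indifferent to the group it carries: a single exchange there is enough to lift the read-out clear of the scatter, which the earlier pair, differing in more than one place, could not show. Compound 2 stands at a limit and not at a number, so the step is known only as a lower bound: the limit of < 10% in this assay, at which 1 of the 3 values shown sits.

Only methoxy and trifluoromethyl are shown at this position, so it stays open whether the gain comes from adding trifluoromethyl or from removing methoxy, and a plain hydrogen, a chlorine, a nitrile or an amine there would help separate the two. As far as these compounds go, it also stays open whether the same exchange gives a comparable step with the other end of the molecule as in compound 1, and, as the read-out comes from one concentration, how it would translate into potency.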